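Swapping a tetrazole for a methylimidazole on a shared core

A few compounds are considered here, and "the series" means these few. Any claim that something is new, unique, unknown or untested is made for them only; others in the source may bear on it.

Of the compounds shown here, two of a shared core have been measured. Compound 1 `CC(C)C(/C=C1\CCNC1=O)c1ccc(-c2ccc3cccc(F)c3c2)[nH]c1=O` carries a five-membered non-aromatic ring with one hetero atom on the saturated chain carbon, and in a physicochemical assay for solubility, in phosphate buffer, measured as kinetic solubility (a lower number here means a less soluble compound, a higher number a more soluble compound), compound 1 gives 20700 nM. Compound 2 `CC(C)C(Cc1nnn[nH]1)c1ccc(-c2ccc3cccc(F)c3c2)[nH]c1=O` replaces that ring with a five-membered aromatic ring with four hetero atoms, and in this assay compound 2 gives 27300 nM. Among the measured compounds shown here, the step of a 1.3-fold higher number from compound 1 to compound 2 (0.12 log units; within the scatter) is the only measured step. Compound 2 stands with the highest of the two numbers, yet its nearest neighbour, compound 1, lies within the scatter of it, so no order between the two can be claimed.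

Compound 3 `Cc1c[nH]c(C(c2ccc(-c3ccc4cccc(F)c4c3)[nH]c2=O)C(C)C)n1` is not yet measured. Its change from compound 2 is 4-methyl-1H-imidazol-2-yl in place of (1H-tetrazol-5-yl)methyl on a saturated chain carbon bound to an aromatic carbon and a saturated chain carbon. For the measured compounds named here, the one step that bears on it, a 1.3-fold higher number from compound 1 to compound 2 (0.12 log units; within the scatter), was within the scatter, which gives no ground to expect a large step in this assay in either direction for compound 3. He therefore expects compound 3 to give about 20000 nM in this assay, between 7000 nM and 55000 nM. The expected step is a 1.4-fold lower number from compound 2 to compound 3 (0.14 log units; within the scatter).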

Compound 3, solubility: 15200 nM
The estimate for compound 3 lay 1.3-fold (0.12 log units) above the measured number, and the stated range covers the measured number.
By their numbers in this assay, from the lowest: compounds 3, 1 and 2 (each within the scatter of the next).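

At the place on a saturated chain carbon bound to an aromatic carbon and a saturated chain carbon, 4-methyl-1H-imidazol-2-yl in place of (1H-tetrazol-5-yl)methyl gives, in this assay, a 1.8-fold lower number from compound 2 to compound 3 (0.25 log units; within the scatter), and the group of compound 3 in place of the non-aromatic ring of compound 1 gives a 1.4-fold lower number from compound 1 to compound 3 (0.13 log units; within the scatter). Three different groups have now stood at this place, and every step among them lies within the scatter, even where the group goes from 3 hydrogen-bond acceptors to 1 hydrogen-bond acceptor and the attachment goes from a methyl link to the ring itself, so this assay does not separate these compounds. No measurement is available that would tie these numbers to any property of the groups.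

The compounds shown leave open whether a group of another kind at this place, such as a carboxylic acid or a primary amine, would give a step beyond the scatter in this assay. They also leave open whether a longer chain carrying the 4-methyl-1H-imidazol-2-yl group would stay within the scatter of compound 3.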